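Working notes: from compound 3 to compound 4

The source may hold more compounds than are shown below. What is called first, only, known or untested is meant among the compounds shown, and "the series" means these compounds.

Values in a functional assay on PC-3 cells (Homo sapiens) for antiproliferative activity, read by MTT assay, with a stated time of 48 h; a higher number here means a weaker inhibitor, a lower number a stronger inhibitor:
- compound 1 `COc1ccc(CN(C(=O)CSc2nc3ccccc3s2)c2cc(OC)c(OC)c(OC)c2)cc1N=[N+]=[N-]`: 14400 nM
- compound 2 `COc1ccc(CN(C(=O)CSc2nc3ccccc3s2)c2cc(OC)c(OC)c(OC)c2)cc1`: 8460 nM
- compound 3 `COc1ccc(CN(C(=O)CSc2nc3ccccc3s2)c2cc(OC)c(OC)c(OC)c2)cc1[N+](=O)[O-]`: 26500 nM

Compound 3 has the highest number of the three, but that position is only partly secure. Its gap on one side is a 1.8-fold higher number from compound 1 to compound 3 (0.26 log units; within the scatter), while on the other it is a 3.1-fold higher number from compound 2 to compound 3 (0.50 log units; beyond the scatter).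

The next compound is compound 4 `COc1cc(N(Cc2ccccc2)C(=O)CSc2nc3ccccc3s2)cc(OC)c1OC`. The change is phenyl in place of 4-methoxy-3-nitrophenyl on a saturated chain carbon bound to an amide-type nitrogen, with phenyl in place of 4-methoxy-3-nitrophenyl on a saturated chain carbon bound to an amide-type nitrogen. Cut one bond further out, this reads 4-methoxy-3-nitrobenzyl to benzyl.

The most relevant measured step is a 3.1-fold higher number from compound 2 to compound 3 (0.50 log units; beyond the scatter), which introduces the nitro that compound 4 lacks. Reversing it points to a lower number in this assay. The other two steps add little: a 1.7-fold lower number from compound 1 to compound 2 (0.23 log units; within the scatter) and a 1.8-fold higher number from compound 1 to compound 3 (0.26 log units; within the scatter). Going by the values given here, no measured step shows what removing the methoxy does, so the range has to stay wide. A modest move is therefore expected, with the estimated step being a 2.7-fold lower number from compound 3 to compound 4 (0.42 log units; beyond the scatter). The expected value for compound 4 is 10000 nM, with an estimated range of 4000 nM to 25000 nM.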

Compound 4, half-maximal inhibitory concentration: 54100 nM
For compound 4 the middle estimate is 5.4-fold (0.73 log units) below the measured one, outside the stated range (above it).
By their numbers in this assay, from the lowest: compounds 2, 1 and 3 (each within the scatter of the next, the first and the last beyond it); then compound 4.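

In this assay, going by these compounds alone, taking off the methoxy alone gives a 6.4-fold higher number from compound 2 to compound 4 (0.81 log units; beyond the scatter), so this position on the benzyl group responds to a change that the earlier compounds, which all kept the methoxy, could not show. Compound 4 has no nitro, yet the move to plain benzyl still gives a 2.0-fold higher number from compound 3 to compound 4 (0.31 log units; beyond the scatter), and the azido counterpart gives a 3.8-fold higher number from compound 1 to compound 4 (0.57 log units; beyond the scatter) in the same direction, so the unsubstituted benzyl stands above all three substituted compounds and the nitro step read from compound 2 does not carry over once the methoxy is gone. No measurement on hand accounts for these steps.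

Open, as far as these compounds go, is whether the methoxy itself matters or whether another group in its place, such as a hydroxyl, an ethoxy or a fluorine, would keep the number near that of compound 2. Also open, from the compounds shown here alone, is how a nitro or an azido behaves on a benzyl group without the methoxy, which would separate the two changes that are combined in the steps to compound 4 from compound 3 and compound 1.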